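The source may hold more compounds than are shown below. What is called first, only, known or untested is meant among the compounds shown, and "the series" means these compounds.

Working notes on the series. Compound 1 `Cc1cc(=O)n(-c2ccccc2C(F)(F)F)nc1C(=O)Nc1ccc(Oc2ncnc3ccsc23)cc1` and compound 2 `Cc1cc(=O)n(-c2ccc(Br)cc2F)nc1C(=O)Nc1ccc(Oc2ncnc3ccsc23)cc1` share one arrangement of the group on the aromatic oxygen; compound 3 `Cc1cc(=O)n(-c2ccccc2C(F)(F)F)nc1C(=O)Nc1ccc(Oc2ncnc3sccc23)cc1` carries the other arrangement, and compound 4 `Cc1cc(=O)n(-c2ccc(Br)cc2F)nc1C(=O)Nc1ccc(Oc2ncnc3sccc23)cc1` combines that arrangement with the substituent on the aromatic nitrogen found in compound 2. In a functional assay on HepG2 cells (Homo sapiens) for cytotoxicity, read by MTT assay, with a stated time of 72 h (on this read-out higher numbers stand for weaker inhibition and lower numbers for stronger inhibition), compound 1 gives 9230 nM and compound 2 gives 10600 nM. For compound 3 this assay reports only a limit, > 40000 nM, so compound 3 stands at the edge of the measured range (the limit of > 40000 nM in this assay, at which 1 of the 3 values shown sits). Going by the values given here, the step of an at least 4.3-fold higher number from compound 1 to compound 3 (0.63 log units; beyond the scatter) is the one change that moved the number beyond the scatter. The change from compound 3 to compound 4 is 4-bromo-2-fluorophenyl in place of 2-(trifluoromethyl)phenyl on an aromatic nitrogen. The same exchange on the other arrangement of the oxygen-linked group, a 1.1-fold higher number from compound 1 to compound 2 (0.06 log units; within the scatter), stayed within the scatter. No shift beyond the scatter is therefore expected in this assay, a step that the limit leaves unreadable from compound 3 to compound 4. Compound 4 is expected to give about 45000 nM, within a range of 20000 nM to 100000 nM, most probably reported again only as a limit.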

Compound 4, half-maximal inhibitory concentration: 6300 nM
The estimate for compound 4 lay 7.1-fold (0.85 log units) above the measured number; measured number outside the range, below it.
By their numbers in this assay, from the lowest: compounds 4, 1 and 2 (each within the scatter of the next). At a limit, above all of these: compound 3.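

In this assay the exchange of 2-(trifluoromethyl)phenyl for 4-bromo-2-fluorophenyl on the aromatic nitrogen gives an at least 6.3-fold lower number from compound 3 to compound 4 (0.80 log units; beyond the scatter), so the size of this step depends on the arrangement of the oxygen-linked group: the same change on two cores in this assay, a 1.1-fold higher number (0.06 log units; within the scatter) from compound 1 to compound 2 and an at least 6.3-fold lower number (0.80 log units; beyond the scatter) from compound 3 to compound 4, at least 7.2-fold (0.86 log units) apart, beyond the scatter of two such steps. The reverse also holds, since the change of arrangement gives a 1.7-fold lower number from compound 2 to compound 4 (0.23 log units; within the scatter) when 4-bromo-2-fluorophenyl is the substituent, and the loss seen with 2-(trifluoromethyl)phenyl does not carry over: the same change on two cores in this assay, an at least 4.3-fold higher number (0.63 log units; beyond the scatter) from compound 1 to compound 3 and a 1.7-fold lower number (0.23 log units; within the scatter) from compound 2 to compound 4, at least 7.2-fold (0.86 log units) apart, beyond the scatter of two such steps. Compound 3 alone stands apart from the other compounds, and its value is a limit: the limit of > 40000 nM in this assay, at which 1 of the 4 values shown sits.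

Whether the bromine or the fluorine of 4-bromo-2-fluorophenyl accounts for the step on this arrangement remains open. Also open, going by these compounds, is whether a phenyl carrying an amine or a carboxylic acid on the aromatic nitrogen would follow compound 3 or compound 4 on this arrangement.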